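A few compounds are considered here, and "the series" means these few. Any claim that something is new, unique, unknown or untested is made for them only; others in the source may bear on it.

Compound 1 `CCCc1ccc(C(=O)Nc2cc(C(=O)O)cc(C(=O)O)c2)cc1` was tested in a functional assay on the whole organism (stomach) with Rattus norvegicus as the target (on this read-out higher numbers stand for an effect only at larger amounts of compound and lower numbers for an effect already at smaller amounts), where compound 1 gives 94.2 mg/kg. Of the two numbers available, this is the higher one; compound 2 `O=C(O)c1ccc(NC(=O)c2ccc(C(=O)O)cc2)cc1` gives 54.3 mg/kg in this assay, a gap that lies within the usual scatter, so the two cannot be told apart. Compound 3 `O=C(O)c1cc(NC(=O)c2ccc([N+](=O)[O-])cc2)cc(C(=O)O)c1` differs from compound 1 in one place: nitro in place of propyl on an aromatic carbon. Within the data shown here, no measured pair shows what this change does, so the step from compound 1 to compound 3 is expected to be small, a 1.0-fold lower number from compound 1 to compound 3 (0.02 log units; within the scatter), with no clear direction beyond the scatter. Compound 3 is therefore estimated at 90 mg/kg in this assay, within a range from 40 mg/kg to 200 mg/kg.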

Compound 3, dose for 50% inhibition: 61.1 mg/kg
Compound 3: the middle estimate sits 1.5-fold (0.17 log units) above what was measured; low and high end bracket the measured number.
By their numbers in this assay, from the lowest: compounds 2, 3 and 1 (each within the scatter of the next).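

Nitro in place of propyl on this aromatic carbon, para to a large group, gives a 1.5-fold lower number from compound 1 to compound 3 (0.19 log units; within the scatter) in this assay on the shared core. Two groups of equal heavy-atom count, one all carbon and the other of nitrogen and oxygen, therefore cannot be told apart at this position, something compounds 1 and 2 could not show, as they differ in more than one place. Nothing at hand bears on this result. Going by these compounds, whether an amine or a longer chain here would shift the number beyond the scatter remains open.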